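Swapping Bromo for Methyl on the Shared Core

The compounds below may be only part of what the source reports. "The series", "measured", "known", "first", "only" and "open" are said of these compounds alone.

Compound 1 `CN(C)c1ccc(/C=C/c2cc(-c3nnc(N)s3)c3cc(Br)ccc3n2)cc1` gives 7.7 ug/mL
Compound 2 `CCOC(=O)C(C#N)C(=O)c1cc(/C=C/c2ccc(N(C)C)cc2)nc2ccc(Br)cc12` gives 7.7 ug/mL

In a functional assay on HCT-116 cells (Homo sapiens) for cytotoxicity (on this read-out higher numbers stand for weaker inhibition and lower numbers for stronger inhibition), compound 1 gives 7.7 ug/mL and stands level with compound 2 at 7.7 ug/mL in this small set. Compound 3 `Cc1ccc2nc(/C=C/c3ccc(N(C)C)cc3)cc(-c3nnc(N)s3)c2c1` keeps the core of compound 1 and differs in one place. The change methyl in place of bromo on an aromatic carbon puts methyl in place of bromo on an aromatic carbon of a six-membered aromatic ring of carbon only, part of a fused or bridged system of two rings.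

Within the data shown here, only one measured step is available, and it bears on this change only indirectly. The step of no change at the digits printed from compound 1 to compound 2 (within the scatter) stays within the scatter, yet it replaces 5-amino-1,3,4-thiadiazol-2-yl and leaves the bromo untouched. Among the measured compounds shown here, no measurement yet shows what replacing the bromo does. No step beyond the scatter is therefore expected in this assay and no direction is favoured, though the uncertainty stays wide. The estimated step of a 1.0-fold higher number from compound 1 to compound 3 (0.02 log units; within the scatter) is expected to remain within the scatter. The estimate for compound 3 is 8 ug/mL with an expected range from 3.5 ug/mL to 18 ug/mL once it is measured.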

Compound 3, half-maximal inhibitory concentration: 7.7 ug/mL
Estimate against measurement, compound 3: 1.0-fold (0.02 log units) above, and the stated range covers the measured number.
By their numbers in this assay, from the lowest: compounds 1, 2 and 3 (each within the scatter of the next).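

In this assay, no change at the digits printed from compound 1 to compound 3 (within the scatter) when methyl stands in place of bromo on the aromatic carbon of the shared core, so this swap gives no step beyond the scatter. Among these compounds, the earlier step had changed only the 5-amino-1,3,4-thiadiazol-2-yl group and left the bromo in place, which makes this the first reading at this position, and it shows that the read-out does not depend on keeping the bromo, at least where methyl is the replacement. No measured evidence bears on why bromo and methyl read alike here.

The compounds shown leave open whether this position stays as flat for groups other than these two, since a methoxy, an amine or a carboxylic acid on the same aromatic carbon could still move the number in either direction. They also leave open whether methyl would read the same alongside (cyano(ethoxycarbonyl)methyl)carbonyl rather than 5-amino-1,3,4-thiadiazol-2-yl, as this swap has been read with only the latter group on the core.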